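The source may report more compounds than this note shows. Statements on the series, on what has been measured and on what is new or still open speak of the compounds shown alone.

Of the compounds shown here, three sharing one core have been measured in an ADME assay on microsomes from liver (Canis lupus familiaris) for metabolic stability, read by LC-MS, using NADPH, with a stated time of 30 min, tested at 1 uM; on this read-out lower numbers stand for a less stable compound and higher numbers for a more stable compound. Compound 1 `C=CC(=O)Nc1cc(Nc2ncc(F)c(Nc3ccccc3S(=O)(=O)N(C)C)n2)c(OC)cc1N(C)CCN(C)C` gives 33%, compound 2 `C=CC(=O)Nc1cc(Nc2ncc(Cl)c(Nc3ccccc3S(=O)(=O)N(C)C)n2)c(OC)cc1N(C)CCN(C)C` gives 31% and compound 3 `C=CC(=O)Nc1cc(Nc2ncc(F)c(Nc3ccccc3S(=O)(=O)C(C)C)n2)c(OC)cc1N(C)CCN(C)C` gives 27%, so compound 3 stands within the scatter of both others. Compound 4 `C=CC(=O)Nc1cc(Nc2nccc(Nc3ccccc3S(=O)(=O)C(C)C)n2)c(OC)cc1N(C)CCN(C)C` differs from compound 3 by hydrogen in place of fluoro on an aromatic carbon, with hydrogen in place of fluoro on an aromatic carbon. The measured step closest to this change is a number 2 percentage points lower from compound 1 to compound 2 (within the scatter), which has chloro in place of fluoro on an aromatic carbon. The other step, a number 6 percentage points lower from compound 1 to compound 3 (within the scatter), has isopropyl in place of dimethylamino on a sulfonyl sulfur and concerns a different part of the structure. Among the measured compounds shown here, neither step exceeds the scatter, although no measured pair shows the loss of the halogen itself. No change beyond the scatter is therefore expected in this assay, and the estimated step is a number 1 percentage points higher from compound 3 to compound 4 (within the scatter). Compound 4 is estimated at 28%, with an expected range from 16% to 41%.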

Compound 4, percent of the compound remaining: 48%
Estimate against measurement, compound 4: 20 percentage points below, outside the stated range (above it).
By their numbers in this assay, from the lowest: compounds 3, 2 and 1 (each within the scatter of the next); then compound 4.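

In this assay, removing the halogen itself, which no earlier pair covered, gives a number 21 percentage points higher from compound 3 to compound 4 (beyond the scatter), the only step shown that lies beyond the scatter. This position therefore matters to the read-out, although exchanging one halogen for another there, a number 2 percentage points lower from compound 1 to compound 2 (within the scatter), did not show it: chloro in place of fluoro stays within the scatter, while hydrogen in place of fluoro does not. Nothing available accounts for this difference between the two changes.

The compounds shown leave open whether hydrogen in place of fluoro gives a similar step when dimethylamino rather than isopropyl sits on the sulfonyl sulfur, as in compound 1. They also leave open how a small non-halogen group, such as methyl or nitrile, would read at this position.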